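Methyl for Trifluoromethyl: Expecting a Flat Step

The source may report more compounds than this note shows. Statements on the series, on what has been measured and on what is new or still open speak of the compounds shown alone.

In an assay on PMNL cells for inhibition of Polyunsaturated fatty acid 5-lipoxygenase (Homo sapiens), read by HPLC, with stated times of 5 min and 15 min (a lower number here means a stronger inhibitor, a higher number a weaker inhibitor), three compounds have been measured so far:

compound 1 `COc1cc(/C=C/C(=O)OCCc2cccc(C(F)(F)F)c2)cc(OC)c1O` gives 200 nM
compound 2 `COc1cc(/C=C/C(=O)OCCc2ccccc2C(F)(F)F)cc(OC)c1O` gives 350 nM
compound 3 `COc1cc(/C=C/C(=O)OCCc2cccc(C)c2)cc(OC)c1O` gives 200 nM

Compound 2 holds the highest of these three numbers, but its distance from compound 1 and from compound 3 is within the usual scatter of this assay, so none of the three can be called stronger or weaker than another on this evidence.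

The next compound, compound 4 `COc1cc(/C=C/C(=O)OCCc2ccccc2C)cc(OC)c1O`, is made from compound 2 by one change: methyl in place of trifluoromethyl on an aromatic carbon. The same kind of swap has already been seen once, between compound 1 and compound 3, where the trifluoromethyl also gave way to a methyl on an aromatic carbon; there the result was no change at the digits printed from compound 1 to compound 3 (within the scatter). Among the compounds with values here, that single precedent is the only measured step that bears on the move from compound 2 to compound 4, and it suggests that exchanging these two groups on this ring leaves this assay essentially untouched.

On that basis the step is expected to be a 1.2-fold lower number from compound 2 to compound 4 (0.07 log units; within the scatter), no movement beyond the scatter in either direction. Compound 4 is therefore estimated at 300 nM, with a likely range from 150 nM to 700 nM.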

Compound 4, half-maximal inhibitory concentration: 240 nM
Compound 4: the middle estimate sits 1.3-fold (0.10 log units) above what was measured; low and high end bracket the measured number.
By their numbers in this assay, from the lowest: compounds 1, 3, 4 and 2 (each within the scatter of the next).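

In this assay, methyl in place of trifluoromethyl has now been read at a second place on the ring, ortho to a large group, and the result is a 1.5-fold lower number from compound 2 to compound 4 (0.16 log units; within the scatter). Moving the methyl itself, with 2-methylphenyl in place of 3-methylphenyl, gives a 1.2-fold higher number from compound 3 to compound 4 (0.08 log units; within the scatter), so among these four compounds neither the swap of group nor this shift of the methyl produces a difference larger than the usual spread between repeated measurements. The swap also reads alike in both settings, which makes the flat result more than a single observation: the same change on two cores in this assay, no change at the digits printed (within the scatter) from compound 1 to compound 3 and a 1.5-fold lower number (0.16 log units; within the scatter) from compound 2 to compound 4, 1.5-fold (0.16 log units) apart, within the scatter of two such steps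

These compounds carry only trifluoromethyl or methyl on this ring, so they leave open whether a different kind of group, such as an amine, a carboxylic acid or a methoxy group, would move the number beyond that spread. They also leave open what a longer chain carrying the ring would do, since every compound shown has the same chain.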